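This account rests on a few compounds, and the source may have more. Where it says the series, first, only, none or still open, it means among the compounds named here.

In a functional assay on MIA PaCa-2 cells (Homo sapiens) for inhibition, read by MTT assay, with a stated time of 3 days (a lower number here means a stronger inhibitor, a higher number a weaker inhibitor), compound 1, whose structure is `CCOC(=O)[C@@H]1CCCN(S(=O)(=O)c2ccc(S(=O)(=O)N3CCCCC3)cc2)C1`, gives > 10000 nM, and this is a limit of the assay rather than a measured number. Compound 2, with the structure `CC(C)c1noc(N2CCN(C(=O)[C@@H]3CCCN(S(=O)(=O)c4ccc(S(=O)(=O)C5CCC5)cc4)C3)CC2)n1`, also reaches only a limit in this assay, namely > 10000 nM. Compound 3, drawn as `CCN(CC)S(=O)(=O)c1ccc(S(=O)(=O)N2CCC[C@@H](C(=O)NC3CN(C(=O)NC(C)(C)C)C3)C2)cc1`, likewise stops at a limit in this assay, reading > 10000 nM. Every value shown is therefore (the limit of > 10000 nM in this assay, at which 3 of the 3 values shown sit), so compound 2 stands nowhere apart from its companions: none of the three has a measured potency, and no ranking among them is possible.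

Compound 4, with the structure `CC(C)c1noc(N2CCN(C(=O)[C@@H]3CCCN(S(=O)(=O)c4ccc(S(=O)(=O)NC5CCC5)cc4)C3)CC2)n1`, differs from compound 2 in one place, described as cyclobutylamino in place of cyclobutyl on a sulfonyl sulfur, or, read one bond further out, cyclobutylsulfonyl to cyclobutylsulfamoyl. Among the compounds with values here, no pair of measured compounds separated by a single change exists here, so no measured step size can guide the expectation. With compound 2 sitting at a limit, the expected step is a step that the limit leaves unreadable from compound 2 to compound 4, meaning no change beyond the usual scatter in either direction. Compound 4 is accordingly estimated at 15000 nM, within a range from 5000 nM to 50000 nM, and it is expected most likely to be reported again only as a limit.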

Compound 4, half-maximal inhibitory concentration: > 10000 nM
Compound 4 gave a limit, no number; the forecaster's own chance of this, stated with the estimate: 80%; the middle value is on the limit's open side.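

Compound 2 and compound 4 both stop at a limit, so no step can be read for the change from cyclobutyl to cyclobutylamino on a sulfonyl sulfur. The compounds shown leave open how they rank against one another in this assay, because none has yet given a measured number: the limit of > 10000 nM in this assay, at which 4 of the 4 values shown sit.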